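The source may report more compounds than this note shows. Statements on the series, on what has been measured and on what is new or still open speak of the compounds shown alone.

Three compounds share one core and differ only in the aromatic group attached to an amine nitrogen in a ring. Compound 1 `CCC(C(=O)N1CCN(c2cccc(OC)c2)CC1)N1C(=O)CCC1=O` carries a 3-methoxyphenyl there, compound 3 `CCC(C(=O)N1CCN(c2ccc(F)cc2)CC1)N1C(=O)CCC1=O` a 4-fluorophenyl, and compound 2 `CCC(C(=O)N1CCN(c2ccc(C(F)(F)F)cc2)CC1)N1C(=O)CCC1=O` carries a trifluoromethyl on an aromatic carbon where compound 3 carries a fluoro. In a functional assay on the whole organism (strain Swiss) with Mus musculus as the target, in the maximal electroshock model, with a stated time of 2 h, at a dose of 300 mg/kg by the intraperitoneal route (on this read-out lower numbers stand for a weaker effect and higher numbers for a stronger effect at the one dose given), compound 1 gives 0%, compound 2 gives 0%, and compound 3 gives 0%. Compound 3 thus stands level with both of its neighbours: the step of no change at the digits printed from compound 1 to compound 3 (within the scatter) and the step of no change at the digits printed from compound 2 to compound 3 (within the scatter) show that neither exchange of the aromatic group moved the read-out at all.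

Compound 4 `CCC(C(=O)N1CCN(c2cccc(C)c2)CC1)N1C(=O)CCC1=O` is the next member and differs from compound 3 in one place: 3-methylphenyl in place of 4-fluorophenyl on an amine nitrogen in a ring. Both measured steps bear on this change, since each swaps one substituted phenyl for another on the same ring nitrogen, and both were flat. Among the measured compounds shown here, nothing among the measured compounds suggests that a 3-methylphenyl would behave differently, so no step beyond the scatter is expected in this assay, and the expected step of no change at the digits printed from compound 3 to compound 4 (within the scatter) is accordingly flat. Compound 4 is therefore estimated to give 0% in this assay, with a range from 0% to 12%.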

Compound 4, a percentage reported as activity, at one dose (the size of the read-out at that dose, not a potency): 0%
Beside the measured number, compound 4's estimate shows no gap at the digits printed, and the stated range covers the measured number.
By their numbers in this assay, from the lowest: compounds 1, 2, 3 and 4 (each within the scatter of the next).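

this assay now covers a methyl on the aromatic ring as well: replacing 4-fluorophenyl with 3-methylphenyl on the amine nitrogen in a ring gives no change at the digits printed from compound 3 to compound 4 (within the scatter), and replacing methoxy with methyl on an aromatic carbon gives no change at the digits printed from compound 1 to compound 4 (within the scatter). Among the compounds shown here, the second step is the first that compares two groups named at the same ring position, 3-methoxyphenyl and 3-methylphenyl, so neither a swap of substituent at that position nor a swap that also moves the substituent shifts the read-out, although all of these values sit at the bottom of the scale, where a further loss could not appear. No outside information bears on why this read-out stays flat across these four compounds.

On these data alone, it remains open whether any group on this phenyl ring, such as an amine or a carboxylic acid, can raise the read-out above the bottom of the scale. As far as these compounds go, it is equally open whether the flat result belongs to the aromatic group at all, or whether a change elsewhere on the shared core, such as a longer chain, would be needed to produce an effect.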